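Double-bond geometry in a free-amine ether: compound 4

The compounds below may be only part of what the source reports. "The series", "measured", "known", "first", "only" and "open" are said of these compounds alone.

All results below come from a functional assay on PK9 cells (Homo sapiens) for inhibition, read by MTT assay, with a stated time of 72 h; a lower number here means a stronger inhibitor, a higher number a weaker inhibitor.
Compound 1, `CCCCCCCC/C=C\CCCCCCCCOC[C@@H]1CCCN1C(=O)OC(C)(C)C`: > 100000 nM, a limit of the assay.
Compound 2, `CCCCCCCC/C=C/CCCCCCCCOC[C@@H]1CCCN1C(=O)OC(C)(C)C`: > 100000 nM, a limit of the assay.
Compound 3, `CCCCCCCC/C=C\CCCCCCCCOC[C@@H]1CCCN1`: 6500 nM.

Among the compounds with values here, compound 3 stands as the only true number among the three results; the other two are limits. In this assay compound 3 sits far from compound 1, the step of an at least 15-fold lower number from compound 1 to compound 3 (1.18 log units; beyond the scatter) coming with hydrogen in place of tert-butoxycarbonyl on the ring amine. Compound 4, `CCCCCCCC/C=C/CCCCCCCCOC[C@@H]1CCCN1`, differs from compound 3 only as the two compounds have the same atoms and bonds and differ only in configuration as drawn: 1 of 2 stereo elements differ; a double bond is drawn Z in compound 3 and E in compound 4. Within the data shown here, the one measured step of this kind, a step that the two limits leave unreadable from compound 1 to compound 2, cannot be read because of the limit of > 100000 nM in this assay, at which 2 of the 3 values shown sit, so it gives no direction. The step expected, a 1.1-fold higher number from compound 3 to compound 4 (0.03 log units; within the scatter), is small. Compound 4 is therefore expected to give 7000 nM, estimated between 2000 nM and 25000 nM.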

Compound 4, half-maximal inhibitory concentration: 9200 nM
For compound 4 the middle estimate is 1.3-fold (0.12 log units) below the measured one; low and high end bracket the measured number.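

With the ring amine free, double-bond geometry can finally be read in this assay: the step is a 1.4-fold higher number from compound 3 to compound 4 (0.15 log units; within the scatter) and lies within the scatter, so drawing the bond Z or E makes no measurable difference here. The matching pair carrying tert-butoxycarbonyl could not show this, as its step is unreadable. Hydrogen in place of tert-butoxycarbonyl now also helps with the E double bond, giving an at least 10-fold lower number from compound 2 to compound 4 (1.03 log units; beyond the scatter) as a large step, so this change works with both geometries. Whether its size differs between them stays unreadable. Also open, on these data alone, is how a methyl group on the ring nitrogen, or a fully saturated chain, would fare.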